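Chloro-substituted arylidene series: cytotoxicity notes

This account rests on a few compounds, and the source may have more. Where it says the series, first, only, none or still open, it means among the compounds named here.

Measured so far:
- compound 1, `O=C1NC(=S)/C(=C/c2cccc(Cl)c2)S1`: 5.44%
- compound 2, `O=C1NC(=S)/C(=C/c2ccccc2Cl)S1`: -11.5%
- compound 3, `O=C1NC(=S)/C(=C/c2ccc(Cl)c(Cl)c2)S1`: 5.03%

All three share the same core and differ only in the chloro pattern on the aromatic ring. In a functional assay on HEp-2 cells (Homo sapiens) for cytotoxicity, read by MTT assay, with a stated time of 72 h, tested at 2.5 ug/mL (on this read-out higher numbers stand for more inhibition of growth at the one concentration tested and lower numbers for less inhibition of growth), compound 1 gives 5.44%, and compound 3 gives 5.03%. The step between them, a number 0.4 percentage points lower from compound 1 to compound 3 (within the scatter), is chloro in place of hydrogen on an aromatic carbon. Compound 2 gives -11.5%, the lowest of the three; its nearest neighbour is compound 3 and its furthest compound 1, both beyond the scatter. Compound 2 and compound 1 have the same atoms joined differently; the difference between the two cores is not broken down here.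

The unmeasured compound 4, `O=C1NC(=S)/C(=C/c2ccc(Cl)cc2Cl)S1`, arises from compound 2 by chloro in place of hydrogen on an aromatic carbon. This is the same kind of change as from compound 1 to compound 3, not the same: in compound 3 the entering chloro sits ortho to a chloro group, in compound 4 it sits meta to a chloro group. Among the measured compounds shown here, the one measured instance of adding a chloro, from compound 1 to compound 3, left the read-out within the scatter. On that basis a similarly small step, a number 3.5 percentage points higher from compound 2 to compound 4 (within the scatter), is expected from compound 2 to compound 4 in this assay, since compound 2 starts from -11.5%. Compound 4 is therefore estimated at -8%, with a range from -25% to 10%.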

Compound 4, percent growth inhibition at one concentration: 15.3%
Estimate against measurement, compound 4: 23.3 percentage points below; measured number outside the range, above it.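

In this assay, chloro in place of hydrogen on an aromatic carbon does not carry over as a step of constant size from the core of compound 1 to the core of compound 2: the same change on two cores in this assay, a number 0.4 percentage points lower (within the scatter) from compound 1 to compound 3 and a number 26.8 percentage points higher (beyond the scatter) from compound 2 to compound 4, 27.2 percentage points apart, beyond the scatter of two such steps The larger step is a number 26.8 percentage points higher from compound 2 to compound 4 (beyond the scatter), and in compound 4 the entering chloro sits meta to a chloro group and para to a group of 8 heavy atoms, whereas the other step is a number 0.4 percentage points lower from compound 1 to compound 3 (within the scatter), so a step read on one of these cores is a poor guide to the same change on the other. Among the compounds shown here, this does not show why the two steps differ or whether the position of the entering chloro, the position of the chloro already present, or both matter, since the two pairs differ in both respects and only one pair has been read on each core, at a single concentration.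

The compounds shown leave open how a fluoro group, a methoxy group or an amine would compare with chloro at the same ring position. They also leave open where an aromatic ring carrying no chloro at all would fall in this assay.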